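The compounds below may be only part of what the source reports. "The series", "measured", "known", "first", "only" and "open" are said of these compounds alone.

Measured so far:
- compound 1, `N#CNC(=N)Nc1cccnc1`, 50 mg/kg
- compound 2, `CC(C)C/N=C(\NC#N)Nc1cccnc1`, 20 mg/kg
- compound 3, `CC(C)(C)C/N=C(/NC#N)Nc1cccnc1`, 2.5 mg/kg

All three were tested in a functional assay on the whole organism (blood, strain Wistar-Okamoto) with Rattus norvegicus as the target, with a stated time of 5 days; a lower number here means that less compound is needed, a higher number that more compound is needed for the effect. Compound 2 stands second highest of the three numbers: compound 1 needs a higher dose, compound 3 a lower one, and both gaps lie beyond the usual scatter. Compound 4, `CC(C)C(C)(C)/N=C(\NC#N)Nc1cccnc1`, has not yet been measured. It differs from compound 2 in one place: 1,1,2-trimethylpropyl in place of isobutyl on a double-bonded nitrogen. Among the measured compounds, the larger and more branched group on the double-bonded nitrogen, in compound 3, goes with the lowest dose, while the unsubstituted compound 1 needs the most. On that basis compound 4 is expected to need a lower dose than compound 2, a step of a 4.0-fold lower number from compound 2 to compound 4 (0.60 log units; beyond the scatter) beyond the scatter. For compound 4 the estimate is 5 mg/kg, within a range of 1.5 mg/kg to 20 mg/kg.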

Compound 4, minimum effective dose: 1 mg/kg
Beside the measured number, compound 4's estimate is 5.0-fold (0.70 log units) above it; the measured number lies below the stated range.
By their numbers in this assay, from the lowest: compound 4; then compound 3; then compound 2; then compound 1.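

In this assay, 1,1,2-trimethylpropyl in place of isobutyl on a double-bonded nitrogen gives a 20-fold lower number from compound 2 to compound 4 (1.30 log units; beyond the scatter) and is a large step. Within the data shown here, it is the only step here in which one group changes while the rest of the structure stays the same, so it shows that this position alone can shift the required dose strongly. Nothing shown explains the shift. The compounds shown leave open how a cyclohexyl group or a straight hexyl chain would behave at this position.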